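Changing the Urea Aryl Group of Compound 3

The compounds below may be only part of what the source reports. "The series", "measured", "known", "first", "only" and "open" are said of these compounds alone.

Compound 3 `CS(=O)(=O)Nc1cccc(NC(=O)Nc2cccc(-c3nc(-c4ccc(NC(=O)c5cccnc5)cc4Cl)no3)c2)c1` is the weak end of a small urea series built on a shared core. In a functional assay on MDA-MB-231 cells (Homo sapiens) for antiproliferative activity, read by MTT assay, with a stated time of 72 h (on this read-out lower numbers stand for stronger inhibition and higher numbers for weaker inhibition), compound 3 gives only a limit, > 10000 nM. Compound 1 `O=C(Nc1ccc(Cl)cc1)Nc1cccc(-c2nc(-c3ccc(NC(=O)c4cccnc4)cc3Cl)no2)c1` also gives only a limit in this assay, > 10000 nM. Compound 2 `COc1cccc(NC(=O)Nc2cccc(-c3nc(-c4ccc(NC(=O)c5cccnc5)cc4Cl)no3)c2)c1` gives 6700 nM in this assay. The step of an at least 1.4-fold lower number from compound 1 to compound 2 (0.17 log units; that floor lies within the scatter) is small, the step of an at least 1.4-fold higher number from compound 2 to compound 3 (0.17 log units; that floor lies within the scatter) is small as well, and the step that the two limits leave unreadable from compound 1 to compound 3 cannot be sized, since (the limit of > 10000 nM in this assay, at which 2 of the 3 values shown sit). Compound 4 `CC(=O)Nc1ccc(NC(=O)Nc2cccc(-c3nc(-c4ccc(NC(=O)c5cccnc5)cc4Cl)no3)c2)cc1Cl` differs from compound 3 by 4-acetamido-3-chlorophenyl in place of 3-(methanesulfonamido)phenyl on an amide-type nitrogen. None of the three measured steps moves this assay beyond its scatter, and the two aryl variations that keep a halogen or a sulfonamide both land at the limit, so a further aryl swap of this kind is expected to leave the read-out weak. Compound 4 is therefore estimated at 10000 nM, within 4000 nM to 30000 nM. The expected step of a number no higher from compound 3 to compound 4 (the limit leaves the size open) is estimated to stay within the scatter.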

Compound 4, half-maximal inhibitory concentration: > 10000 nM
Compound 4: no number, only a limit; the forecaster's own chance of this, stated with the estimate: 60%; the middle value lies on the limit itself.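

Putting 4-acetamido-3-chlorophenyl on the amide-type nitrogen shows that an aryl group carrying both an acetamido group and a chlorine also fails to give a number in this assay, where compound 4 has only a limit. The steps linking compound 4 to compound 1 and compound 3 cannot be read, since all three compounds have only limits: the limit of > 10000 nM in this assay, at which 3 of the 4 values shown sit. The one readable step is an at least 1.4-fold higher number from compound 2 to compound 4 (0.17 log units; that floor lies within the scatter), so this change is not shown to move the read-out beyond the scatter.

Going by these compounds, how far any of the three limit compounds lies past that limit remains open. Also open, on these data alone, is whether a free amine or a carboxylic acid on this aryl group, or a longer alkyl chain in its place, would give a value clear of the limit.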